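Removing the Aromatic Methyl: An Expected Toxicity for Compound 3

This account rests on a few compounds, and the source may have more. Where it says the series, first, only, none or still open, it means among the compounds named here.

Compound 1, `C=CCNC(=O)/C(C)=C(\C)c1ccc(OC)cc1`: 300 mg/kg
Compound 2, `C=CCNC(=O)/C(C)=C(\C)c1ccc(C)cc1`: 150 mg/kg

Of the compounds shown here, two have been measured in a toxicity assay on the whole organism (strain Icem-CET (SPF Caw)) for cytotoxicity, with Mus musculus as the target; a lower number here means that less compound is needed, a higher number that more compound is needed for the effect. Compound 2 gives 150 mg/kg. Going by the values given here, its only neighbour among the measured compounds is compound 1, and the step of a 2.0-fold lower number from compound 1 to compound 2 (0.30 log units; within the scatter) lies within the scatter, so the two compounds stand together rather than apart.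

Compound 3, `C=CCNC(=O)/C(C)=C(\C)c1ccccc1`, has not yet been measured. It differs from compound 2 by hydrogen in place of methyl on an aromatic carbon. Among the compounds with values here, the one measured step that bears on this change is a 2.0-fold lower number from compound 1 to compound 2 (0.30 log units; within the scatter), which also altered the group on an aromatic carbon of the same ring and stayed within the scatter. Within the data shown here, nothing measured so far points to a step beyond the scatter for an exchange at that carbon, and the structural change here is a small one.

Compound 3 is therefore expected to give 200 mg/kg in this assay, with a range from 90 mg/kg to 450 mg/kg. This estimate means a step of a 1.3-fold higher number from compound 2 to compound 3 (0.12 log units; within the scatter), which is expected to remain within the scatter.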

Compound 3, dose for half-maximal effect: 250 mg/kg
Compound 3: the middle estimate sits 1.3-fold (0.10 log units) below what was measured; low and high end bracket the measured number.
By their numbers in this assay, from the lowest: compounds 2, 3 and 1 (each within the scatter of the next).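

Going by these compounds alone, with compound 3, this place on the ring, para to a large group, can be read with no group on it at all, whereas the earlier pair showed only one group exchanged for another. In this assay, taking away the methyl leaves the number within the scatter (a 1.7-fold higher number from compound 2 to compound 3 (0.22 log units; within the scatter)), and hydrogen in place of methoxy does the same (a 1.2-fold lower number from compound 1 to compound 3 (0.08 log units; within the scatter)), so hydrogen, methyl and methoxy on this aromatic carbon stand together, and neither group separates its compound from the one that carries hydrogen there. No measurement at hand offers an explanation for these numbers.

As far as these compounds go, the three compounds cover only a narrow set of groups, so it remains open whether something of another kind at this carbon, such as an amine, a carboxylic acid, a chlorine atom or a longer chain, would give a step beyond the scatter. They also leave open whether changes elsewhere on the shared core would move the number further than any exchange at this place has done.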